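Bromo to Iodo: What Compound 4 Should Tolerate

A few compounds are considered here, and "the series" means these few. Any claim that something is new, unique, unknown or untested is made for them only; others in the source may bear on it.

Three measured compounds share one core and differ only in what sits on the six-membered aromatic ring of carbon only at the end of the chain. Compound 1 `O=c1cc(CNCc2ccccc2)oc2ccc(O)c(O)c12` carries no group there. In an ADME assay on Huh-7 cells (Homo sapiens) for cytotoxicity (a higher number here means that more compound is tolerated, a lower number that less compound is tolerated), compound 1 reaches only a limit of the assay, > 100000 nM. Compound 2 `O=c1cc(CNCc2ccccc2O)oc2ccc(O)c(O)c12` carries a hydroxy group; in this assay compound 2 also stops at a limit, > 100000 nM. Compound 3 `O=c1cc(CNCc2cccc(Br)c2)oc2ccc(O)c(O)c12` carries a bromo group; in this assay compound 3 likewise sits at a limit, > 100000 nM. Because every value rests at the same limit of > 100000 nM in this assay, at which 3 of the 3 values shown sit, none of the steps can be sized: a step that the two limits leave unreadable from compound 1 to compound 2, a step that the two limits leave unreadable from compound 1 to compound 3 and a step that the two limits leave unreadable from compound 2 to compound 3 all remain unreadable. Compound 3 therefore stands level with the other two, without a number of its own.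

Compound 4 `O=c1cc(CNCc2cccc(I)c2)oc2ccc(O)c(O)c12` follows the change (iodo in place of bromo on an aromatic carbon). All steps that could bear on it are unreadable, so the expected step is a number no higher from compound 3 to compound 4 (the limit leaves the size open), nothing beyond the scatter. Compound 4 is estimated at 100000 nM, with a range from 30000 nM to 300000 nM, and is expected most likely to be reported again only as a limit.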

Compound 4, half-maximal cytotoxic concentration: > 100000 nM
Compound 4: no number, only a limit; the forecaster's own chance of this, stated with the estimate: 85%; the middle value lies on the limit itself.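

Compound 4 stops at a limit, as compound 1, compound 2 and compound 3 do, so no step among these four compounds can be read: the limit of > 100000 nM in this assay, at which 4 of the 4 values shown sit.

The compounds shown leave open how much of each is tolerated in this assay, and whether hydroxy, bromo, iodo or no group there makes any difference.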